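This account rests on a few compounds, and the source may have more. Where it says the series, first, only, none or still open, it means among the compounds named here.

Compound 3, `COc1ccc2[nH]c(CC(CC(=O)O)c3ccc(Cl)cc3)nc2c1`, is measured in an assay on isolated protein for inhibition of protein kinase C zeta type (Homo sapiens), read by 33P incorporation, tested at 50 uM (on this read-out lower numbers stand for a weaker effect and higher numbers for a stronger effect at the one concentration tested), at 0%. This puts compound 3 level with compound 1, `O=C(O)CC(Cc1nc2cc(F)ccc2[nH]1)c1ccc(Cl)cc1`, which gives 0%; together they stand lowest of the three. Compound 2, `O=C(O)CC(Cc1nc2cc(C(F)(F)F)ccc2[nH]1)c1ccc(Cl)cc1`, gives 35%, and the change a number 35 percentage points lower from compound 2 to compound 3 (beyond the scatter) is large. The new compound 4, `COC(=O)c1ccc2[nH]c(CC(CC(=O)O)c3ccc(Cl)cc3)nc2c1`, differs from compound 3 by methoxycarbonyl in place of methoxy on an aromatic carbon. Among the measured compounds shown here, the steps that bear on this position are a number 35 percentage points higher from compound 1 to compound 2 (beyond the scatter) and a number 35 percentage points lower from compound 2 to compound 3 (beyond the scatter), both large, showing that the group on this aromatic carbon can move the read-out a good deal, while neither involves a methoxycarbonyl. A step of a number 15 percentage points higher from compound 3 to compound 4 (beyond the scatter) is therefore expected, with considerable uncertainty. Compound 4 is estimated at 15%, within a range from 0% to 40%.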

Compound 4, a percentage reported as inhibition, at one concentration (the size of the read-out at that concentration, not a potency): 0%
Beside the measured number, compound 4's estimate is 15 percentage points above it; the range from low to high includes it.
By their numbers in this assay, from the lowest: compounds 1, 3 and 4 (each within the scatter of the next); then compound 2.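

In this assay, methoxycarbonyl on this aromatic carbon gives no change at the digits printed from compound 3 to compound 4 (within the scatter) and no change at the digits printed from compound 1 to compound 4 (within the scatter), while a number 35 percentage points lower from compound 2 to compound 4 (beyond the scatter) leaves trifluoromethyl the only one of the four groups shown with a read-out beyond the scatter of the others. The larger methoxycarbonyl, with its carbonyl, therefore does not lift the number over methoxy. Nothing measured here accounts for trifluoromethyl standing apart. Compounds reading zero cannot be told apart at this one concentration. As far as these compounds go, whether a nitrile, an amine or a carboxylic acid on this carbon would raise the read-out remains open.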